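Fluorobenzyl to ester sulfide: a step without a readable anchor

This account rests on a few compounds, and the source may have more. Where it says the series, first, only, none or still open, it means among the compounds named here.

Measured compounds:
- Compound 1 `COc1cc(-c2nnc(SC)n2/N=C/c2ccccc2)cc(OC)c1OC`: in a functional assay on MCF7 cells (Homo sapiens) for cytotoxicity, read by MTT assay, with a stated time of 48 h (a lower number here means a stronger inhibitor, a higher number a weaker inhibitor), compound 1 gives > 200000 nM, which is a limit of the assay.
- Compound 2 `COc1cc(-c2nnc(SCc3ccc(F)cc3)n2/N=C/c2ccccc2)cc(OC)c1OC`: in this assay compound 2 gives > 200000 nM, again only a limit.
- Compound 3 `COc1ccc(/C=N/n2c(SCc3ccc(F)cc3)nnc2-c2cc(OC)c(OC)c(OC)c2)c(OC)c1`: in this assay compound 3 gives > 200000 nM, likewise a limit.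

Every value in the set sits at the limit of > 200000 nM in this assay, at which 3 of the 3 values shown sit, so nothing can be ranked: the two steps between these compounds, a step that the two limits leave unreadable from compound 1 to compound 2 and a step that the two limits leave unreadable from compound 2 to compound 3, leave their size unknown. Compound 3 thus stands at a limit, with no number of its own and nothing to compare it with.

Compound 4 `CCOC(=O)CSc1nnc(-c2cc(OC)c(OC)c(OC)c2)n1/N=C/c1ccc(OC)cc1OC` differs from compound 3 in one place: ethoxycarbonyl in place of 4-fluorophenyl on a saturated chain carbon bound to a sulfur. Within the data shown here, the only measured step at that same place, the one from compound 1 to compound 2, is itself unreadable, so no measured step gives a size or direction for this change. With three limits and no readable step, the expectation for compound 4 is simply that it stays where the others sit. For compound 4 the step is expected to be a number no higher from compound 3 to compound 4 (the limit leaves the size open). The estimate for compound 4 is 200000 nM, with a range from 50000 nM to 1000000 nM, and most likely the assay will again report only a limit.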

Compound 4, half-maximal inhibitory concentration: > 200000 nM
Compound 4: a limit, no number (the forecaster's own chance of this, stated with the estimate: 80%); the middle value lies on the limit itself.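

In this assay compound 4 gives > 200000 nM, which is again a limit and not a number. The step between compound 3 and compound 4 therefore cannot be read, and neither can any other step here: the limit of > 200000 nM in this assay, at which 4 of the 4 values shown sit.

The compounds shown leave open how they truly rank and which change to the shared core, if any, would give a readable number.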